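This account rests on a few compounds, and the source may have more. Where it says the series, first, only, none or still open, it means among the compounds named here.

Of the compounds shown here, three of one shared core have been measured in a functional assay on CCRF-CEM cells (Homo sapiens) for inhibition; a higher number here means that more compound is tolerated, a lower number that less compound is tolerated. Compound 1 `O=C1c2ccccc2N(COCc2ccccc2)S(=O)(=O)N1Cc1ccccc1` gives 25000 nM. Compound 2 `O=C1c2ccccc2N(COCc2ccccc2)S(=O)(=O)N1COCc1ccccc1`, which carries a benzyloxy in place of one phenyl, gives 27700 nM; compound 3 `O=C1c2ccccc2N(Cc2ccccc2)S(=O)(=O)N1Cc1ccc(Cl)cc1` gives 27800 nM. Compound 1 therefore stands together with compound 2 and compound 3: all three numbers lie within the usual scatter of one another, and nothing separates them.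

Compound 4 `O=C(OCOCN1c2ccccc2C(=O)N(Cc2ccccc2)S1(=O)=O)c1ccccc1` has not yet been measured. It differs from compound 1 by benzoyloxy in place of phenyl on a saturated chain carbon bound to an oxygen on a saturated carbon. Among the compounds with values here, the one measured step that resembles this change is the exchange of phenyl for benzyloxy on the carbon bound to the ring nitrogen, which gave a 1.1-fold higher number from compound 1 to compound 2 (0.04 log units; within the scatter). The change to compound 4 also lengthens a chain ending in a phenyl, on the other side of the core, and the small step seen from compound 1 to compound 2 suggests that such an extension leaves the number roughly where it is. No step beyond the scatter is expected in this assay, in either direction. For compound 4 the expected value is 27000 nM, between 12000 nM and 60000 nM, which is a step of a 1.1-fold higher number from compound 1 to compound 4 (0.03 log units; within the scatter) and is expected to stay within the scatter.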

Compound 4, half-maximal cytotoxic concentration: 100000 nM
The estimate for compound 4 lay 3.7-fold (0.57 log units) below the measured number; measured number outside the range, above it.
By their numbers in this assay, from the lowest: compounds 1, 2 and 3 (each within the scatter of the next); then compound 4.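

In this assay, within the data shown here, benzoyloxy in place of phenyl on a saturated chain carbon bound to an oxygen on a saturated carbon gives a 4.0-fold higher number from compound 1 to compound 4 (0.60 log units; beyond the scatter), the first step in this small set to pass beyond the scatter. The earlier exchange, benzyloxy in place of phenyl on a saturated chain carbon bound to an amide-type nitrogen in a ring, gave only a 1.1-fold higher number from compound 1 to compound 2 (0.04 log units; within the scatter), so the number does not stay put for every extension of a chain ending in a phenyl. Nothing available explains why this change moves the number.

The compounds shown leave open whether the step belongs to the carbonyl or to the whole benzoyloxy. An acetyloxy, which keeps the carbonyl but has no phenyl, and a longer carbon chain ending in phenyl, which has no carbonyl, would separate the two.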